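A few compounds are considered here, and "the series" means these few. Any claim that something is new, unique, unknown or untested is made for them only; others in the source may bear on it.

Measured compounds:
- Compound 1 `COc1ccc2c(c1)c(/C=C1/C(=O)Nc3ccc(F)cc31)cn2Cc1cn([C@@H]2O[C@H](COC(C)=O)[C@@H](OC(C)=O)[C@H](OC(C)=O)[C@H]2OC(C)=O)nn1`: in a functional assay on HeLa cells (Homo sapiens) for cytotoxicity, read by sulforhodamine B assay, with a stated time of 48 h (on this read-out higher numbers stand for weaker inhibition and lower numbers for stronger inhibition), compound 1 gives > 200000 nM, which is a limit of the assay.
- Compound 2 `CC(=O)OC[C@H]1O[C@@H](n2cc(CN3C(=O)/C(=C\C=C\c4ccccc4)c4ccccc43)nn2)[C@H](OC(C)=O)[C@@H](OC(C)=O)[C@@H]1OC(C)=O`: in this assay compound 2 gives 98100 nM.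
- Compound 3 `CC(=O)OC[C@H]1O[C@@H](n2cc(CN3C(=O)/C(=C/C=C/c4ccccc4)c4ccccc43)nn2)[C@H](OC(C)=O)[C@@H](OC(C)=O)[C@@H]1OC(C)=O`: in this assay compound 3 gives > 100000 nM, which is a limit of the assay.

Compound 3 thus stands at a limit of this assay and has no number of its own (the limit of > 100000 nM in this assay, at which 1 of the 3 values shown sits). Compound 1 likewise sits at a limit (the limit of > 200000 nM in this assay, at which 1 of the 3 values shown sits). Among the measured compounds shown here, the only measured step, an at least 1.0-fold higher number from compound 2 to compound 3 (0.00 log units; that floor lies within the scatter), rests on the fact that compounds 2 and 3 differ only in the configuration as drawn and lies within the scatter.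

Compound 4 `CC(=O)OC[C@H]1O[C@@H](n2cc(CN3C(=O)/C(=C/c4cccs4)c4ccccc43)nn2)[C@H](OC(C)=O)[C@@H](OC(C)=O)[C@@H]1OC(C)=O` carries thiophen-2-yl in place of 2-phenylethenyl on a double-bonded chain carbon bound to a double-bonded ring carbon. For the measured compounds named here, no measured step involves this exchange; the single step in hand concerns configuration only and tells nothing about the change from compound 3 to compound 4. With compound 3 at a limit and every neighbour weak in this assay, compound 4 is expected to show a number no higher from compound 3 to compound 4 (the limit leaves the size open), nothing beyond the scatter in either direction. Compound 4 is therefore estimated at 100000 nM, with a range from 30000 nM to 300000 nM, and most likely again only a limit.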

Compound 4, half-maximal inhibitory concentration: 36900 nM
Beside the measured number, compound 4's estimate is 2.7-fold (0.43 log units) above it; low and high end bracket the measured number.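

In this assay, thiophen-2-yl in place of 2-phenylethenyl on a double-bonded chain carbon bound to a double-bonded ring carbon gives an at least 2.7-fold lower number from compound 3 to compound 4 (0.43 log units; beyond the scatter). Among the compounds shown here, this is the first step to lie beyond the scatter, so the number at this position does respond to the group it carries, which the earlier step, a matter of configuration alone, could not show. Compound 3 stands at a limit, so this step is only a floor and its full size stays open: the limit of > 100000 nM in this assay, at which 1 of the 4 values shown sits.

The exchange changes the ring and removes the chain double bond together, so the compounds shown do not tell which of the two goes with the lower number. On these data alone, a plain phenyl or a furan-2-yl at this place would separate them, and whether a group carrying an amine is tolerated there also remains open.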